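Hydroxy added ortho to methoxy in two anticonvulsant series

A few compounds are considered here, and "the series" means these few. Any claim that something is new, unique, unknown or untested is made for them only; others in the source may bear on it.

Measured compounds:
- compound 1, `COc1ccc(/C=C/C(=O)Nc2nc3ccc([N+](=O)[O-])cc3s2)cc1`, 315 umol/kg
- compound 2, `COc1ccc(C2CC(Nc3nc4ccc(C)cc4s3)=NN2C(C)=O)cc1`, 37.3 umol/kg
- compound 3, `COc1ccc(C2CC(Nc3nc4ccc(C)cc4s3)=NN2C(C)=O)cc1O`, 73.9 umol/kg

All three were run in a functional assay on the whole organism (Hindlimb, strain albino) with Mus musculus as the target, in the maximal electroshock model, with a stated time of 0.5 h; on this read-out lower numbers stand for an effect already at smaller amounts and higher numbers for an effect only at larger amounts of compound. Compound 2 gives 37.3 umol/kg and compound 3 gives 73.9 umol/kg; the two share a core and differ only by hydroxy in place of hydrogen on an aromatic carbon, which produced a 2.0-fold higher number from compound 2 to compound 3 (0.30 log units; within the scatter). Compound 1, with a different core, gives 315 umol/kg in this assay, the highest of the three numbers; its gap to compound 3 and to compound 2 lies beyond the scatter. The difference between the core of compound 1 and the core of compound 2 is not broken down here.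

Compound 4, `COc1ccc(/C=C/C(=O)Nc2nc3ccc([N+](=O)[O-])cc3s2)cc1O`, has not yet been measured. It stands to compound 1 as compound 3 stands to compound 2: the change is hydroxy in place of hydrogen on an aromatic carbon, the same change at the same place, since the surroundings of the place read identically in both pairs. Among the compounds with values here, the only guide to its size is the step from compound 2 to compound 3, which stayed within the scatter. Within the data shown here, for compound 4 the expected step in this assay is therefore a 1.6-fold higher number from compound 1 to compound 4 (0.20 log units; within the scatter), resting on the single earlier step of a 2.0-fold higher number from compound 2 to compound 3 (0.30 log units; within the scatter) and on the value of compound 1, 315 umol/kg; with one precedent on a different core, the range is kept wide. Compound 4 is estimated at 500 umol/kg, between 230 umol/kg and 1200 umol/kg.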

Compound 4, dose for half-maximal effect: 372 umol/kg
Compound 4: middle estimate off by 1.3-fold (0.13 log units), on the high side; measured number inside the range.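

In this assay, hydroxy in place of hydrogen on an aromatic carbon, ortho to a methoxy group, gives a 1.2-fold higher number from compound 1 to compound 4 (0.07 log units; within the scatter), so on the core of compound 1 the step again stays within the scatter. Set beside the earlier step, the two cores show no measurable difference in how this change reads: the same change on two cores in this assay, a 2.0-fold higher number (0.30 log units; within the scatter) from compound 2 to compound 3 and a 1.2-fold higher number (0.07 log units; within the scatter) from compound 1 to compound 4, 1.7-fold (0.22 log units) apart, within the scatter of two such steps. In this series the change therefore carries from one core to the other as a step too small to read on either, but two pairs in a single assay do not show that the hydroxy group is without any effect, nor that the same would hold on a third core.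

The compounds shown leave open whether an amine or a carboxylic acid at this place on the ring, or a longer chain in place of the methoxy group, would give a step beyond the scatter on either core. As far as these compounds go, the parts that set the two cores apart are also not separated in these pairs, so it remains open which of them, if any, would alter the size of the step.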